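The source may hold more compounds than are shown below. What is called first, only, known or untested is meant among the compounds shown, and "the series" means these compounds.

In a functional assay on DU-145 cells (Homo sapiens) for antiproliferative activity, read by WST assay, with a stated time of 3 days (on this read-out higher numbers stand for weaker inhibition and lower numbers for stronger inhibition), the account starts from compound 1 `CCCCCOc1c(-c2cc(OC)c(OC)c(OC)c2)oc2ccccc2c1=O` and compound 2 `CCCN(CCC)CCCOc1c(-c2cc(OC)c(OC)c(OC)c2)oc2ccccc2c1=O`. Compound 1 gives > 50000 nM, which is a limit of the assay and not a number. Compound 2 gives > 50000 nM, which is also a limit. Compound 2 therefore has no measured potency, and the only other result beside it offers no number either: the limit of > 50000 nM in this assay, at which 2 of the 2 values shown sit.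

Compound 3 `CCCN(CCC)CCCCCOc1c(-c2cc(OC)c(OC)c(OC)c2)oc2ccccc2c1=O` keeps the shared core and differs only in its chain: 2-(dipropylamino)ethyl in place of dipropylamino on a saturated chain carbon, three bonds along the chain from an oxygen on an aromatic ring. In words, 2-(dipropylamino)ethyl replaces dipropylamino on a saturated chain carbon, three bonds along the chain from an oxygen on an aromatic ring.

Among the compounds with values here, only one measured step bears on this change, a step that the two limits leave unreadable from compound 1 to compound 2. It has no readable size, so it gives no measure of how far a change in this chain can move the result in this assay. Any expectation is therefore tentative, and another limit remains quite possible. For compound 3 the expected step is an at least 1.6-fold lower number from compound 2 to compound 3 (0.22 log units; that floor lies within the scatter), towards stronger inhibition if a number is obtained at all. Compound 3 is estimated at 30000 nM, with an expected range of 8000 nM to 50000 nM.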

Compound 3, half-maximal inhibitory concentration: 24200 nM
The estimate for compound 3 lay 1.2-fold (0.09 log units) above the measured number; low and high end bracket the measured number.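

Within the data shown here, compound 3 gives the first true number in this set in this assay. Lengthening the chain from 3-(dipropylamino)propyl to 5-(dipropylamino)pentyl brings an at least 2.0-fold lower number from compound 2 to compound 3 (0.31 log units; beyond the scatter), and placing dipropylamino on the end of the plain chain of compound 1 brings an at least 2.0-fold lower number from compound 1 to compound 3 (0.31 log units; beyond the scatter); both sizes are floors, as each step starts from a limit of the assay and not from a number. Among these compounds, then, a number appears only where the dipropylamino group and the longer chain occur together, whereas compound 1, with the chain but no amine, and compound 2, with the amine on the shorter chain, both stay at the limit: the limit of > 50000 nM in this assay, at which 2 of the 3 values shown sit.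

From the compounds shown here alone, how far each step really reaches remains open, and the step from compound 1 to compound 2 cannot be read at all. Also open, going by these compounds, is whether a still longer chain would carry the result further towards stronger inhibition, and whether a different amine, such as piperidine or morpholine, could stand in place of dipropylamino at the end of the pentyl chain.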